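The compounds below may be only part of what the source reports. "The series", "measured", "known", "first", "only" and "open" are said of these compounds alone.

For the measured compounds named here, compound 2 `CN1CCN(c2ccc([N+](=O)[O-])c(C(F)(F)F)c2)CC1` gives 88.3% in an assay on isolated protein for inhibition of NAD-dependent protein deacylase sirtuin-6 (Homo sapiens), tested at 300 uM (on this read-out higher numbers stand for more inhibition at the one concentration tested (going by the name of the read-out) and lower numbers for less inhibition), the lower of the two numbers measured so far. Going by the values given here, compound 1 `CN1CCN(c2ccc([N+](=O)[O-])c(O)c2)CC1` gives 119%, and the only measured step, a number 30.7 percentage points lower from compound 1 to compound 2 (beyond the scatter), came with trifluoromethyl in place of hydroxy on an aromatic carbon. Compound 3 `CN1CCN(c2ccc([N+](=O)[O-])c(NCc3ccccc3)c2)CC1` differs from compound 2 by benzylamino in place of trifluoromethyl on an aromatic carbon. Among the compounds with values here, no measured step exchanges trifluoromethyl for benzylamino, so the one known step bears on it only loosely and the direction is uncertain. Compound 3 is expected to give about 100%, between 70% and 125%. The expected step is a number 11.7 percentage points higher from compound 2 to compound 3 (beyond the scatter), a modest rise near the edge of the scatter.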

Compound 3, a percentage reported as inhibition, at one concentration (the size of the read-out at that concentration, not a potency): 96%
Beside the measured number, compound 3's estimate is 4 percentage points above it; measured number inside the range.
By their numbers in this assay, from the lowest: compounds 2 and 3 (each within the scatter of the next); then compound 1.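

At this position, ortho to a nitro group, swapping trifluoromethyl for benzylamino, with its six-membered aromatic ring and hydrogen-bond donor, makes no clear difference in this assay: the result is a number 7.7 percentage points higher from compound 2 to compound 3 (within the scatter). Hydroxy remains distinct, since benzylamino in its place gives a number 23 percentage points lower from compound 1 to compound 3 (beyond the scatter). Nothing available explains these differences.

From the compounds shown here alone, whether a plain amino group or a carboxylic acid at this position would read like compound 1, or like compound 2 and compound 3, remains open.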